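Swapping cyano for fluoro on compound 3

A few compounds are considered here, and "the series" means these few. Any claim that something is new, unique, unknown or untested is made for them only; others in the source may bear on it.

In a functional assay on MT4 cells (Homo sapiens) for cytotoxicity, read by MTT assay (on this read-out higher numbers stand for lower toxicity in this test and lower numbers for higher toxicity in this test), compound 3 (`Cc1c(O)nc(SCc2cccc(C#N)c2)nc1Cc1c(Cl)cccc1Cl`) gives > 60000 nM, which is a limit of the assay and not a number. Compound 1 (`Cc1c(O)nc(SCc2ccc(C#N)cc2)nc1Cc1c(Cl)cccc1Cl`) gives > 60000 nM, also a limit. Compound 2 (`Cc1c(O)nc(SCc2ccc(Cl)cc2)nc1Cc1c(Cl)cccc1Cl`) gives > 59000 nM, again a limit. Compound 3 therefore stands with the other two, and this assay has yet to give a plain number for this small set.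

The next structure is compound 4 (`Cc1c(O)nc(SCc2cccc(F)c2)nc1Cc1c(Cl)cccc1Cl`), with fluoro in place of cyano on an aromatic carbon. The closest comparison, with chloro in place of cyano, is a step that the two limits leave unreadable from compound 1 to compound 2. The other two comparisons are a step that the two limits leave unreadable from compound 1 to compound 3 and a step that the two limits leave unreadable from compound 2 to compound 3. None of these steps has a readable size, so they offer no sign of a change in either direction, and no step beyond the usual scatter is expected. The expected step is a number no higher from compound 3 to compound 4 (the limit leaves the size open). Compound 4 is estimated at 60000 nM, with an expected range from 30000 nM to 100000 nM.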

Compound 4, half-maximal cytotoxic concentration: > 61000 nM
Compound 4: no number, only a limit; the forecaster's own chance of this, stated with the estimate: 85%; middle value at least 1.0-fold (0.00 log units) away from the limit.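

In this assay compound 4 gives > 61000 nM, a limit of the assay and not a number. For the compounds shown here, compound 1, compound 2 and compound 3 also show only limits, so no step from any of them to compound 4 can be read. The compounds shown leave open whether swapping cyano, chloro or fluoro changes this read-out at all.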